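The source may hold more compounds than are shown below. What is called first, only, known or untested is meant among the compounds shown, and "the series" means these compounds.

Of the compounds shown here, three sharing a common carboxamide-bearing core have been measured. In an ADME assay on MRC5 cells (Homo sapiens) for antiproliferative activity, read by fluorescence and resazurin assay, with a stated time of 68 h (on this read-out lower numbers stand for an effect already at smaller amounts and higher numbers for an effect only at larger amounts of compound), compound 1 `Cc1ccc(-c2cc(C(=O)Nc3cccnc3)c3cc(F)ccc3n2)cc1` gives 50000 nM, and compound 2 `Cc1ccc(-c2cc(C(=O)NCCCN(C)C)c3cc(Cl)ccc3n2)cc1` gives 6000 nM. Compound 3 `Cc1cc(Nc2cc(C(=O)NCCN3CCCC3)c3cc(F)ccc3n2)on1` reads > 50000 nM in this assay, which is a limit and not a number; it is the limit of > 50000 nM in this assay, at which 1 of the 3 values shown sits.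

The next step starts from compound 3 and leads to compound 4 `CN1CCN(c2cc(C(=O)NCCN3CCCC3)c3cc(F)ccc3n2)CC1`, which keeps the amide side of compound 3 and changes one substituent. Here 4-methylpiperazin-1-yl takes the place of (3-methyl-1,2-oxazol-5-yl)amino on an aromatic carbon, next to the ring nitrogen: 4-methylpiperazin-1-yl in place of (3-methyl-1,2-oxazol-5-yl)amino on an aromatic carbon. The new group has no hydrogen-bond donor, whereas the group it replaces has one.

Among the measured compounds shown here, no two measured compounds differ in only one place, so the size of this step cannot be read directly from the data. The expectation rests on compound 2, whose 6000 nM shows that a number well under that of compound 1 can occur among these compounds. A moderate move towards smaller numbers in this assay is therefore expected, and the estimated step is an at least 2.0-fold lower number from compound 3 to compound 4 (0.30 log units; that floor lies within the scatter). For compound 4 the estimated value is 25000 nM, with an expected range from 7000 nM to 60000 nM.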

Compound 4, half-maximal effective concentration: 20000 nM
For compound 4 the middle estimate is 1.3-fold (0.10 log units) above the measured one; the measured number falls inside the stated range.
By their numbers in this assay, from the lowest: compound 2; then compound 4; then compound 1.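

Compound 3 reads > 50000 nM in this assay, which is a limit and not a number. Placing 4-methylpiperazin-1-yl instead of (3-methyl-1,2-oxazol-5-yl)amino on this aromatic carbon, next to the ring nitrogen, gives an at least 2.5-fold lower number from compound 3 to compound 4 (0.39 log units; beyond the scatter), so this position affects the read-out even when the entering and leaving groups both hold 7 heavy atoms. This step marks only a floor and its full size stays unknown, because compound 3 stands at a limit: the limit of > 50000 nM in this assay, at which 1 of the 4 values shown sits.

Among the compounds shown here, the single pair leaves open which part of the change goes with the lower number, as the hydrogen-bond donor is lost and a six-membered non-aromatic ring replaces a five-membered aromatic ring in the same step. Going by these compounds, a group such as morpholin-4-yl, a six-membered non-aromatic ring with an oxygen in place of the methylated nitrogen, or a simple dimethylamino group at this position would help to separate these features, and whether any such group would bring the number closer to that of compound 2 also remains open.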